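Methoxy for dimethylamino on the benzofuran-bearing core

The compounds below may be only part of what the source reports. "The series", "measured", "known", "first", "only" and "open" are said of these compounds alone.

Compound 1 `C#Cc1cn([C@@H]2O[C@H](CO)[C@@H](O)[C@H]2O)c2ncnc(N(C)C)c12` serves as the reference of the set. In a functional assay on CEM-DNR-bulk cells (Homo sapiens), read by MTT assay, with a stated time of 72 h (on this read-out lower numbers stand for stronger inhibition and higher numbers for weaker inhibition), compound 1 gives 240 nM. Compound 2 `C#Cc1cn([C@@H]2O[C@H](CO)[C@@H](O)[C@H]2O)c2ncnc(OC)c12` carries the change (methoxy in place of dimethylamino on an aromatic carbon), and in this assay compound 2 gives 3490 nM, so this exchange produced a 15-fold higher number from compound 1 to compound 2 (1.16 log units; beyond the scatter). Compound 3 `CN(C)c1ncnc2c1c(-c1cc3ccccc3o1)cn2[C@@H]1O[C@H](CO)[C@@H](O)[C@H]1O` differs from compound 1 by 1-benzofuran-2-yl in place of ethynyl on an aromatic carbon. For compound 3 in this assay only a limit is known, > 20000 nM. The step of an at least 83-fold higher number from compound 1 to compound 3 (1.92 log units; beyond the scatter) is accordingly bounded by the limit (the limit of > 20000 nM in this assay, at which 1 of the 3 values shown sits). Compound 4 `COc1ncnc2c1c(-c1cc3ccccc3o1)cn2[C@@H]1O[C@H](CO)[C@@H](O)[C@H]1O` has not been measured; it stands to compound 3 as compound 2 stands to compound 1, with methoxy in place of dimethylamino on an aromatic carbon, the same change at the same place. Because compound 3 already sits at the limit of > 20000 nM in this assay, at which 1 of the 3 values shown sits, in this assay and the same exchange once gave a 15-fold higher number from compound 1 to compound 2 (1.16 log units; beyond the scatter), compound 4 is expected to remain out of range. Among the measured compounds shown here, the expected step is a step that the limit leaves unreadable from compound 3 to compound 4, resting on the one earlier instance. For compound 4 in this assay the estimate is 100000 nM, between 20000 nM and 500000 nM, most likely reported again only as a limit.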

Compound 4, half-maximal inhibitory concentration: 10800 nM
The estimate for compound 4 lay 9.3-fold (0.97 log units) above the measured number, outside the stated range (below it).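

In this assay, methoxy in place of dimethylamino does not carry over from the core of compound 1 to the core of compound 3, with an at least 1.8-fold lower number from compound 3 to compound 4 (0.26 log units; that floor lies within the scatter) set against the earlier step: the same change on two cores in this assay, a 15-fold higher number (1.16 log units; beyond the scatter) from compound 1 to compound 2 and an at least 1.8-fold lower number (0.26 log units; that floor lies within the scatter) from compound 3 to compound 4, at least 26-fold (1.43 log units) apart, beyond the scatter of two such steps. The benzofuran exchange also changes in size with the group on the aromatic carbon, now at a 3.1-fold higher number from compound 2 to compound 4 (0.49 log units; beyond the scatter), and it is not a constant increment across the two cores: the same change on two cores in this assay, an at least 83-fold higher number (1.92 log units; beyond the scatter) from compound 1 to compound 3 and a 3.1-fold higher number (0.49 log units; beyond the scatter) from compound 2 to compound 4, at least 26-fold (1.43 log units) apart, beyond the scatter of two such steps. For compound 3 only a limit is known, so the steps that involve it give only floors, and two pairs show that these exchanges do not add up here but give no general rule for the series: the limit of > 20000 nM in this assay, at which 1 of the 4 values shown sits.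

Going by these compounds, it remains open whether another group on the same aromatic carbon, such as a primary amine, ethoxy or methylthio, would follow compound 2 or compound 4. On these data alone, it is equally open whether a smaller aromatic ring such as furan-2-yl or phenyl in place of ethynyl would give steps closer to those of the benzofuran or of the ethynyl core.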